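Swapping the five-membered ring on a pyridinone series

A few compounds are considered here, and "the series" means these few. Any claim that something is new, unique, unknown or untested is made for them only; others in the source may bear on it.

Three compounds share one core and were all checked in a physicochemical assay for solubility, measured as kinetic solubility, at pH 2; on this read-out lower numbers stand for lower solubility and higher numbers for higher solubility. Compound 1 `CC(C)[C@@H](C[C@H]1SC(=O)NC1=O)c1ccc(-c2ccc3cccc(F)c3c2)[nH]c1=O` gives 12200 nM. Compound 2 `C/C(=C1/OC(=O)NC1=O)C(c1ccc(-c2ccc3cccc(F)c3c2)[nH]c1=O)C(C)C` gives 12700 nM. Compound 3 `CCC(/C=C1\OC(=O)NC1=O)(CC)c1ccc(-c2ccc3cccc(F)c3c2)[nH]c1=O` gives 13500 nM. Compound 2 sits among these numbers with its nearest neighbour being compound 1 and its furthest being compound 3, yet both gaps are within the scatter, so the three are read as alike in this assay.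

Compound 4 `CC(C)C(/C=C1/C(=O)NC(=O)N1C)c1ccc(-c2ccc3cccc(F)c3c2)[nH]c1=O` is not yet measured. It differs from compound 2 in one place: a group of 9 heavy atoms (5 carbon, 2 nitrogen, 2 oxygen; one five-membered non-aromatic ring with 2 hetero atoms) in place of a group of 9 heavy atoms (5 carbon, 1 nitrogen, 3 oxygen; one five-membered non-aromatic ring with 2 hetero atoms), on a saturated chain carbon bound to an aromatic carbon and a saturated chain carbon. The change keeps the count of heavy atoms and the single hydrogen-bond donor while one oxygen is exchanged for a nitrogen and one hydrogen-bond acceptor is lost.

Among the measured compounds shown here, no two measured compounds differ in a single place, so no measured step shows how such a swap moves this assay. The three measured values lie in a tight band, which suggests a change of this kind stays within the scatter and points in no clear direction. Compound 4 is therefore expected at 13000 nM with a range from 6000 nM to 28000 nM. The expected step of a 1.0-fold higher number from compound 2 to compound 4 (0.01 log units; within the scatter) is estimated as none beyond the scatter.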

Compound 4, solubility: 8300 nM
For compound 4 the middle estimate is 1.6-fold (0.19 log units) above the measured one; measured number inside the range.
By their numbers in this assay, from the lowest: compounds 4, 1, 2 and 3 (each within the scatter of the next).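

Among the compounds shown here, compound 2 and compound 4 give the first reading of a single change: at the saturated chain carbon bound to an aromatic carbon and a saturated chain carbon, one five-membered non-aromatic ring group is exchanged for another of 9 heavy atoms. In this assay, this gives a 1.5-fold lower number from compound 2 to compound 4 (0.18 log units; within the scatter), so the two compounds read as alike, even though the entering group carries 2 nitrogen and 2 oxygen atoms in place of 1 nitrogen and 3 oxygen atoms, and 2 hydrogen-bond acceptors in place of 3. At this one place, then, that exchange of ring atoms and loss of an acceptor leaves the read-out within its usual scatter, though no measured property is at hand to explain the result.

This is a single step, so it cannot show how far the read-out can move at this position, or whether other ring groups would behave the same way. A basic amine or a carboxylic acid on the same chain carbon lies outside the compounds shown, so its effect on this read-out remains an open question.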